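The compounds below may be only part of what the source reports. "The series", "measured", "known", "first", "only" and "open" are said of these compounds alone.

Compound 1 `Cc1nn(C)c2c1C(c1ccccc1)=NCCN2` and compound 2 `Cc1nn(C)c2c1C(c1ccccc1)=NCCN2C` share a core and differ only in one spot: hydrogen in place of methyl on a nitrogen on an aromatic ring in a ring. In a functional assay on the whole organism for positive allosteric modulation, with Rattus norvegicus as the target (on this read-out higher numbers stand for an effect only at larger amounts of compound and lower numbers for an effect already at smaller amounts), compound 1 gives 2.5 mg/kg, and compound 2 gives 2.5 mg/kg; accordingly no change at the digits printed from compound 1 to compound 2 (within the scatter). Compound 3 `Cc1nn(C)c2c1C(c1cccc(Cl)c1)=NCCN2C` carries one further change, (chloro in place of hydrogen on an aromatic carbon), and in this assay compound 3 gives 0.63 mg/kg, so that a 4.0-fold lower number from compound 2 to compound 3 (0.60 log units; beyond the scatter). The unmeasured compound 4 `Cc1nn(C)c2c1C(c1ccccc1Cl)=NCCN2` arises from compound 1 by the same kind of change, (chloro in place of hydrogen on an aromatic carbon); it is not the same change, since the chloro of compound 3 sits meta to a large group while that of compound 4 sits ortho to a large group. For compound 4 a step of similar size is expected, a 2.5-fold lower number from compound 1 to compound 4 (0.40 log units; beyond the scatter). This expectation rests on compound 3, where a 4.0-fold lower number from compound 2 to compound 3 (0.60 log units; beyond the scatter). Compound 4 is therefore estimated at 1 mg/kg, with a range from 0.3 mg/kg to 3 mg/kg.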

Compound 4, minimum effective dose: 2.5 mg/kg
Beside the measured number, compound 4's estimate is 2.5-fold (0.40 log units) below it; the measured number falls inside the stated range.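

In this assay, chloro in place of hydrogen on an aromatic carbon, here ortho to a large group, brings no change at the digits printed from compound 1 to compound 4 (within the scatter). Set beside the earlier step, the same kind of change does not carry over with the same size: the same change on two cores in this assay, a 4.0-fold lower number (0.60 log units; beyond the scatter) from compound 2 to compound 3 and no change at the digits printed (within the scatter) from compound 1 to compound 4, 4.0-fold (0.60 log units) apart, beyond the scatter of two such steps. This does not show what sets the two steps apart, since compound 3 and compound 4 differ from their parents on different cores and the chloro of compound 3 is not ortho to a large group, so core and place cannot be separated here.

The compounds shown leave open how chloro behaves at each of these two places on the other core. They also leave open how fluoro, methoxy or an amine on the same ring would compare.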